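A few compounds are considered here, and "the series" means these few. Any claim that something is new, unique, unknown or untested is made for them only; others in the source may bear on it.

Series on the shared core of compound 1 `CCOC(=O)c1c(-c2ccc(OC)cc2)[nH]c2cc(OC)ccc2c1=O`, which in a physicochemical assay for solubility, in phosphate buffer, at pH 7.4 (a higher number here means a more soluble compound, a lower number a less soluble compound), gives 8000 nM. Compound 2 `CCOC(=O)c1c(-c2ccc(Cl)cc2)[nH]c2cc(OC)ccc2c1=O` gives 3000 nM, and compound 3 `CCOC(=O)c1c(-c2cccc(Cl)c2)[nH]c2cc(OC)ccc2c1=O` gives 58000 nM, the highest number of the three, beyond the scatter against both others. Among the compounds with values here, the steps so far: a 2.7-fold lower number from compound 1 to compound 2 (0.43 log units; beyond the scatter); a 7.3-fold higher number from compound 1 to compound 3 (0.86 log units; beyond the scatter); a 19-fold higher number from compound 2 to compound 3 (1.29 log units; beyond the scatter). Compound 4 `CCOC(=O)c1c(-c2cccc(C)c2)[nH]c2cc(OC)ccc2c1=O` differs from compound 3 by methyl in place of chloro on an aromatic carbon. Within the data shown here, no measured step exchanges chloro for methyl; the steps that bear on it alter a substituent on the same ring and were modest to large, the largest being the positional one between compound 2 and compound 3. For compound 4 the expected step is a 1.5-fold lower number from compound 3 to compound 4 (0.16 log units; within the scatter), at most a modest move, likely within the scatter. Compound 4 is therefore estimated at 40000 nM, with a range of 15000 nM to 100000 nM.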

Compound 4, solubility: 48000 nM
Beside the measured number, compound 4's estimate is 1.2-fold (0.08 log units) below it; low and high end bracket the measured number.
By their numbers in this assay, from the lowest: compound 2; then compound 1; then compounds 4 and 3 (each within the scatter of the next).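

In this assay the change from 3-chlorophenyl to 3-methylphenyl gives a 1.2-fold lower number from compound 3 to compound 4 (0.08 log units; within the scatter) and so does not separate the two groups at this place. The high level is therefore not tied to chloro among these compounds: there is a 16-fold higher number from compound 2 to compound 4 (1.20 log units; beyond the scatter) and a 6.0-fold higher number from compound 1 to compound 4 (0.78 log units; beyond the scatter) in the same direction as the steps to compound 3. Still open, on these data alone, is whether an amine or a carboxylic acid at this place would keep that level, and whether 4-methylphenyl would match 4-chlorophenyl. No measurement here accounts for these numbers.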